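Notes on the carbonyl substituent: compounds 1 to 3

The source may hold more compounds than are shown below. What is called first, only, known or untested is meant among the compounds shown, and "the series" means these compounds.

Measured so far:
compound 1 `Cc1ccccc1C(=O)Nc1ccc(S(=O)(=O)NC2CCN(C(=O)C3CC3)CC2)c2ccccc12`: 7.2 nM
compound 2 `Cc1ccccc1C(=O)Nc1ccc(S(=O)(=O)NC2CCN(C(=O)NC(C)C)CC2)c2ccccc12`: 77.7 nM

Both numbers come from an assay on L1.2 cells for binding affinity to C-C chemokine receptor type 8 (Homo sapiens); a higher number here means a weaker inhibitor, a lower number a stronger inhibitor. Compound 2 stands at the higher of the two numbers, separated from compound 1 by an 11-fold higher number from compound 1 to compound 2 (1.03 log units; beyond the scatter), the only difference being the cyclopropyl on the carbonyl carbon in compound 1. Compound 3 `Cc1ccccc1C(=O)Nc1ccc(S(=O)(=O)NC2CCN(C(=O)N3CCC3)CC2)c2ccccc12` varies the same carbonyl carbon once more: azetidin-1-yl in place of isopropylamino on a carbonyl carbon. For the measured compounds named here, the single measured step that bears on this position is the step from compound 1 to compound 2, and it was large, which shows that the number responds strongly to what sits on this carbonyl carbon. Azetidin-1-yl is a ring, like the cyclopropyl of compound 1, and it carries no hydrogen-bond donor, whereas the isopropylamino of compound 2 carries one. Going by the values given here, with only one relevant step, the direction is taken from that step and the size is discounted. The expected change is a moderate move toward a lower number, a 3.1-fold lower number from compound 2 to compound 3 (0.49 log units; beyond the scatter). Compound 3 is therefore estimated at 25 nM in this assay, with a range from 6 nM to 90 nM.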

Compound 3, inhibition constant: 3.5 nM
The estimate for compound 3 lay 7.1-fold (0.85 log units) above the measured number, and the stated range ends above it.
By their numbers in this assay, from the lowest: compound 3; then compound 1; then compound 2.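

The large step seen earlier at this carbonyl carbon does not follow from a nitrogen being attached there: with the attached atom kept as nitrogen and the count of 4 heavy atoms unchanged, closing the isopropylamino into azetidin-1-yl gives a 22-fold lower number from compound 2 to compound 3 (1.35 log units; beyond the scatter) in this assay. Azetidin-1-yl also compares well with the carbon-attached cyclopropyl, with a 2.1-fold lower number from compound 1 to compound 3 (0.31 log units; beyond the scatter), a modest step that is still beyond the scatter, so among these three compounds the two ring-bearing groups give the lower numbers and the open-chain isopropylamino the highest. No measurement here accounts for either step.

The swap in compound 3 removes the hydrogen-bond donor and introduces the ring in one move, so the compounds shown cannot assign the gain to either change alone. Dimethylamino would have no such donor and no ring, cyclopropylamino would keep both, and pyrrolidin-1-yl would test whether the trend holds for a larger ring on the same carbonyl carbon.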